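Swapping chloro for iodo on a fused two-ring core

The source may hold more compounds than are shown below. What is called first, only, known or untested is meant among the compounds shown, and "the series" means these compounds.

Compound 1, `O=[N+]([O-])C1=Cc2cccc(I)c2OC1C(F)(F)F`: in an assay on 1321N1 cells for antagonist activity at P2Y purinoceptor 6 (Homo sapiens), read by FLIPR and calcium flux (on this read-out lower numbers stand for stronger inhibition and higher numbers for weaker inhibition), compound 1 gives 4090 nM.
Compound 2, `O=[N+]([O-])C1=Cc2cccc(Cl)c2OC1C(F)(F)F`: compound 2 gives 3690 nM.
Compound 3, `O=[N+]([O-])C1=Cc2c(Cl)cccc2OC1C(F)(F)F`: compound 3 gives 15700 nM.

Compound 4, `O=[N+]([O-])C1=Cc2c(I)cccc2OC1C(F)(F)F`, has not yet been measured. It arises from compound 3 by iodo in place of chloro on an aromatic carbon. The same change has already been made once, from compound 2 to compound 1, (iodo in place of chloro on an aromatic carbon), and there it gave a 1.1-fold higher number from compound 2 to compound 1 (0.04 log units; within the scatter). How the core of compound 3 differs from that of compound 2 is not broken down here; the two values simply show that compound 3 gives a higher number than compound 2, with a gap beyond the scatter. Going by the values given here, since the one earlier instance of this change stayed within the scatter, the step now expected is likewise small, a 1.1-fold higher number from compound 3 to compound 4 (0.03 log units; within the scatter). Compound 4 is therefore estimated at 17000 nM, most likely between 8000 nM and 36000 nM.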

Compound 4, half-maximal inhibitory concentration: 13100 nM
Estimate against measurement, compound 4: 1.3-fold (0.11 log units) above; the measured number falls inside the stated range.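

In this assay, iodo in place of chloro on an aromatic carbon now gives a 1.2-fold lower number from compound 3 to compound 4 (0.08 log units; within the scatter), so the swap again leaves the number practically unchanged. On these two cores the change behaves alike, and the two steps do not differ: the same change on two cores in this assay, a 1.1-fold higher number (0.04 log units; within the scatter) from compound 2 to compound 1 and a 1.2-fold lower number (0.08 log units; within the scatter) from compound 3 to compound 4, 1.3-fold (0.12 log units) apart, within the scatter of two such steps. This shows that the result carried over between these two cores, but it does not show that it would hold on any other core, nor does it explain why the numbers stay so close.

The compounds shown leave open what a nitrile or an amine would do on the same aromatic carbon. They also leave open what would happen if a carboxylic acid took the place of the nitro group.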